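The source may hold more compounds than are shown below. What is called first, only, known or untested is meant among the compounds shown, and "the series" means these compounds.

Measured compounds:
compound 1 `CCCOC(=O)C1=C(C)NC(=O)NC1c1ccco1` — 206 nM
compound 2 `CC1=C(C(=O)OC(C)C)C(c2ccco2)NC(=O)N1C` — 1150 nM
compound 3 `CCOC(=O)C1=C(C)NC(=S)NC1c1ccoc1` — 43.1 nM

In an assay on HEK293 cells for displacement of a labelled ligand from adenosine receptor A2b (Homo sapiens), with a stated time of 30 min (on this read-out higher numbers stand for weaker inhibition and lower numbers for stronger inhibition), compound 3 gives the lowest of the three numbers. Compound 1 stands nearest, at a value some way higher, and that gap lies beyond the scatter; compound 2 lies furthest off, well beyond the scatter. For the measured compounds named here, compound 1 and compound 2 differ from each other in more than one place, so their pair shows only that compound 2 sits at the weaker end of this set. Going by the values given here, the same holds for compound 3 against either of them: no single-change pair is available among the measured compounds.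

Compound 4 `CC1=C(C(=O)OC(C)C)C(c2ccoc2)NC(=S)N1` keeps the shared core of compound 3 and differs from it in one place only: methyl in place of hydrogen on a saturated chain carbon bound to an oxygen next to a carbonyl group and a saturated chain carbon. Among the compounds with values here, no measured pair isolates this kind of change, so no sized step can be drawn from the data. The expectation is a step of a 1.4-fold higher number from compound 3 to compound 4 (0.14 log units; within the scatter) from compound 3 to compound 4, small and likely within the scatter, in no settled direction. The estimate for compound 4 in this assay is 60 nM, within the range 20 nM to 180 nM.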

Compound 4, inhibition constant: 194 nM
Beside the measured number, compound 4's estimate is 3.2-fold (0.51 log units) below it; measured number above the stated range.
By their numbers in this assay, from the lowest: compound 3; then compounds 4 and 1 (each within the scatter of the next); then compound 2.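

In this assay, for the compounds shown here, going from ethoxycarbonyl to isopropoxycarbonyl gives a 4.5-fold higher number from compound 3 to compound 4 (0.65 log units; beyond the scatter) and so provides the first sized single-change step, showing that this position is not indifferent to one added methyl on the saturated chain carbon bound to the oxygen. The earlier compounds shown here differed from one another in more than one place and could not isolate any change at this position, whereas this step is read on one core with everything else held constant. Nothing available here bears on the reason for the step.

Going by these compounds, whether the number keeps rising with tert-butoxycarbonyl, or what a carboxylic acid at the same position would give, remains open. Also open, on these data alone, is whether the same methyl change gives a step of similar size on the core of compound 1.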